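The source may hold more compounds than are shown below. What is called first, only, known or untested is meant among the compounds shown, and "the series" means these compounds.

Compound 1 `COc1cc(-c2cc(/C=C/C(=O)c3ccc(N)cc3)[nH]n2)cc(OC)c1OC` gives 1360 nM in a functional assay on UO-31 cells (Homo sapiens) for inhibition, read by sulforhodamine B assay, with a stated time of 48 h (on this read-out higher numbers stand for weaker inhibition of growth and lower numbers for stronger inhibition of growth), the second highest of the three numbers in hand; compound 3 `COc1ccc(-c2cc(/C=C/C(=O)c3cc(OC)c(OC)c(OC)c3)[nH]n2)cc1OC` gives 1270 nM, within the scatter of compound 1, while compound 2 `COc1ccc(-c2cc(/C=C/C(=O)c3ccc(N)cc3)[nH]n2)cc1OC` gives 3030 nM. Among the compounds with values here, the single step between compounds that differ in one place, a 2.2-fold higher number from compound 1 to compound 2 (0.35 log units; beyond the scatter), concerns a ring other than the one altered here. Compound 4 `COc1cc(-c2cc(/C=C/C(=O)c3ccc(F)c(F)c3)[nH]n2)cc(OC)c1OC` differs from compound 1 by 3,4-difluorophenyl in place of 4-aminophenyl on a carbonyl carbon. Within the data shown here, no measured step bears on this exchange; the numbers of compound 1 and compound 3, which carry different groups on the same carbonyl carbon, fall within the scatter of each other. A step within the scatter is therefore expected, a 1.1-fold higher number from compound 1 to compound 4 (0.04 log units; within the scatter). Compound 4 is estimated at 1500 nM, with a range from 600 nM to 4000 nM.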

Compound 4, concentration for 50% growth inhibition: 2630 nM
The estimate for compound 4 lay 1.8-fold (0.24 log units) below the measured number, and the stated range covers the measured number.
By their numbers in this assay, from the lowest: compounds 3, 1, 4 and 2 (each within the scatter of the next, the first and the last beyond it).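

Within the data shown here, the first direct reading of this exchange on a carbonyl carbon gives a 1.9-fold higher number from compound 1 to compound 4 (0.29 log units; within the scatter) in this assay and so shows no clear change. The 4-aminophenyl group, with its hydrogen-bond donor and acceptor, can thus give way to 3,4-difluorophenyl, which has neither, without a step beyond the scatter. Nothing available gives a reason for this result. As far as these compounds go, whether an unsubstituted phenyl, a nitrile-bearing phenyl or a carboxylic acid on the same carbon would stay within the scatter remains open. So does whether 3,4-difluorophenyl would give a similar number on the core of compound 2.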